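Methyl for Bromo on a Fused Aromatic Core

The source may hold more compounds than are shown below. What is called first, only, known or untested is meant among the compounds shown, and "the series" means these compounds.

Compound 1 `O=C(NCCCCc1ccccc1)n1c(=O)oc2cc(Br)ccc21` gives 31 nM in an assay on HEK293 cells for inhibition of acid ceramidase (Homo sapiens), with a stated time of 10 min; a lower number here means a stronger inhibitor, a higher number a weaker inhibitor.
Compound 2 `Cc1ccc2c(c1)oc(=O)n2C(=O)NCCCCc1ccccc1` gives 66 nM in this assay.
Compound 3 `O=C(NCCCCc1ccccc1)n1c(=O)oc2c(Br)cccc21` gives 18 nM in this assay.

Compound 4 `Cc1cccc2c1oc(=O)n2C(=O)NCCCCc1ccccc1` has not yet been measured. Compound 2 differs from compound 1 only by methyl in place of bromo on an aromatic carbon, and that change made a 2.1-fold higher number from compound 1 to compound 2 (0.33 log units; beyond the scatter). Compound 3 is built from the same atoms as compound 1, joined differently; how the two cores differ is not broken down here. Compound 4 differs from compound 3 by methyl in place of bromo on an aromatic carbon. The place is not the same: in the first pair the group sits meta and para to a fused ring, in the second ortho and meta to a fused ring, so this is the same kind of change, not the same one. Compound 3 has the lowest number of the three, with compound 1 within the scatter of it. Resting on the one earlier step of a 2.1-fold higher number from compound 1 to compound 2 (0.33 log units; beyond the scatter), compound 4 is expected to show a 2.1-fold higher number from compound 3 to compound 4 (0.32 log units; beyond the scatter). Compound 4 is thus estimated at 38 nM, likely between 20 nM and 75 nM.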

Compound 4, half-maximal inhibitory concentration: 23 nM
Compound 4: the middle estimate sits 1.7-fold (0.22 log units) above what was measured, and the stated range covers the measured number.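

Methyl in place of bromo gives a 1.3-fold higher number from compound 3 to compound 4 (0.11 log units; within the scatter) in this assay on this second core, so here the swap stays within the scatter, whereas on the core of compound 1 it went just beyond it. Two pairs cannot show that the change always carries over from one core to another, nor whether the place of the group on the ring matters. What can be said is that the two steps agree as far as such measurements can tell: the same change on two cores in this assay, a 2.1-fold higher number (0.33 log units; beyond the scatter) from compound 1 to compound 2 and a 1.3-fold higher number (0.11 log units; within the scatter) from compound 3 to compound 4, 1.7-fold (0.22 log units) apart, within the scatter of two such steps

The compounds shown leave open how other groups at these places, such as an amine or a carboxylic acid, would compare with bromo and methyl. They also leave open whether the same swap behaves alike with a longer chain leading to the phenyl ring.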